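A few compounds are considered here, and "the series" means these few. Any claim that something is new, unique, unknown or untested is made for them only; others in the source may bear on it.

Series notes, one read-out.

Compound 1 `CCCOc1ccc(C(CC(=O)O)c2ccccc2)cc1` gives 4.8 uM in a functional assay on HEK293 cells for agonist activity at Free fatty acid receptor 1 (Homo sapiens), read by calcium flux; a lower number here means that less compound is needed, a higher number that more compound is needed for the effect.
Compound 2 `CCCCCCCOc1ccc(C(CC(=O)O)c2ccccc2)cc1` gives 4.26 uM in this assay.
Compound 3 `O=C(O)CC(c1ccccc1)c1ccc(OCCCC(F)(F)F)cc1` gives 3.16 uM in this assay.

All three share the same core and differ only at the end of the chain on the aromatic oxygen. Compound 2 sits close to both of the others: the step of a 1.1-fold lower number from compound 1 to compound 2 (0.05 log units; within the scatter) and the step of a 1.3-fold lower number from compound 2 to compound 3 (0.13 log units; within the scatter) are each within the scatter, as is the step of a 1.5-fold lower number from compound 1 to compound 3 (0.18 log units; within the scatter). Nothing in these three numbers separates the compounds from one another.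

Compound 4 `COCCCOc1ccc(C(CC(=O)O)c2ccccc2)cc1` has not yet been measured. Its difference from compound 2 is methoxy in place of butyl on a saturated chain carbon, three bonds along the chain from an oxygen on an aromatic ring. Among the compounds with values here, the steps that bear on this change are those at the same chain carbon: hydrogen to butyl, butyl to trifluoromethyl, hydrogen to trifluoromethyl. None of them moved the number beyond the scatter, so the chain end appears tolerant of quite different groups in this assay. Within the data shown here, no measured compound carries an oxygen at that place, so the methoxy step rests on that tolerance alone.

Compound 4 is therefore expected to come in near compound 2, with a step of a 1.1-fold higher number from compound 2 to compound 4 (0.02 log units; within the scatter) that should stay within the scatter. The estimate for compound 4 is 4.5 uM, with a range from 2.2 uM to 9 uM.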

Compound 4, concentration for half-maximal effect: 7.58 uM
The estimate for compound 4 lay 1.7-fold (0.23 log units) below the measured number; the range from low to high includes it.
By their numbers in this assay, from the lowest: compounds 3, 2, 1 and 4 (each within the scatter of the next, the first and the last beyond it).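

Within the data shown here, at this chain carbon, the methoxy end gives the first step in this assay that lies beyond the scatter, a 2.4-fold higher number from compound 3 to compound 4 (0.38 log units; beyond the scatter) and modest in size, so the position is not indifferent to every exchange of chain end. The other two steps, a 1.8-fold higher number from compound 2 to compound 4 (0.25 log units; within the scatter) and a 1.6-fold higher number from compound 1 to compound 4 (0.20 log units; within the scatter), both stay within the scatter, which leaves methoxy set apart from trifluoromethyl alone among the chain ends shown, and not from butyl or from plain hydrogen. No measurement on hand accounts for that single separation between methoxy and trifluoromethyl.

The compounds shown leave open whether the separation belongs to the ether oxygen itself, as a hydroxyl, an amine or a carboxylic acid at the same chain carbon would help to show. Also open, going by these compounds, is whether a longer chain carrying the same oxygen further out, or a single fluorine in place of trifluoromethyl, would fall with compound 4 or with compound 3, and so whether these two chain ends mark the limits of what the position accepts.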